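Notes on a piperazine nitrogen substituent change

This account rests on a few compounds, and the source may have more. Where it says the series, first, only, none or still open, it means among the compounds named here.

compound 1 `CN(C[C@H]1Cc2c(cccc2N2CCN(C3COC3)CC2)CN1)[C@H]1CCCc2cccnc21`: 381 nM
compound 2 `CN(C[C@@H]1Cc2c(cccc2N2CCNCC2)CN1)[C@H]1CCCc2cccnc21`: 313 nM

For the measured compounds named here, in a functional assay on CCRF-CEM cells for antagonist activity at C-X-C chemokine receptor type 4 (Homo sapiens), read by calcium flux, with stated times of 25 min and 90 s (on this read-out higher numbers stand for weaker inhibition and lower numbers for stronger inhibition), compound 1 gives 381 nM, the higher of the two numbers measured so far; compound 2 gives 313 nM, and the gap between the two is within the scatter. Compound 3 `CN1CCN(c2cccc3c2C[C@H](CN(C)[C@H]2CCCc4cccnc42)NC3)CC1` differs from compound 1 by methyl in place of oxetan-3-yl on an amine nitrogen in a ring. Going by the values given here, no measured pair shows this change, so the step is expected to be small, in no fixed direction and not beyond the scatter: a 1.2-fold lower number from compound 1 to compound 3 (0.08 log units; within the scatter). Compound 3 is therefore expected to give about 320 nM, with a range from 130 nM to 800 nM.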

Compound 3, half-maximal inhibitory concentration: 29.6 nM
Beside the measured number, compound 3's estimate is 11-fold (1.03 log units) above it, outside the stated range (below it).
By their numbers in this assay, from the lowest: compound 3; then compounds 2 and 1 (each within the scatter of the next).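

The substituent on this amine nitrogen in a ring proves to be a sensitive point in this assay: 4-methylpiperazin-1-yl in place of 4-(oxetan-3-yl)piperazin-1-yl gives a 13-fold lower number from compound 1 to compound 3 (1.11 log units; beyond the scatter) on an otherwise unchanged core. For the compounds shown here, this is the first measured pair to read this position, and the change removes a ring and its oxygen in a single step. Nothing at hand accounts for the size of this step.

On these data alone, whether the step belongs to the four-membered ring or to its oxygen stays open. A cyclobutyl group on the same nitrogen would separate the two, and an ethyl group would show how far the trend extends beyond methyl.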